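Removing a ring-amine methyl: expected oral exposure

This account rests on a few compounds, and the source may have more. Where it says the series, first, only, none or still open, it means among the compounds named here.

Of the compounds shown here, three have been measured in an ADME assay on the whole organism (Rattus norvegicus, strain Sprague-Dawley) for pharmacokinetics, with a stated time of 6 h, at a dose of 10 mg/kg by the oral route; on this read-out higher numbers stand for higher exposure at the dose given and lower numbers for lower exposure. Compound 1 `Cc1cn2nc(-c3cc(=O)n4cc(N5CCN(C)CC5)ccc4n3)cc2c(C)n1` gives 2100 ng.h/mL in this assay. Compound 3 `Cc1cn2cc(-c3cc4ccc(N5CCN(C)CC5)cc4oc3=O)nc2c(C)n1` gives 530 ng.h/mL, and compound 2 `Cc1cn2cc(-c3cc4ccc(N5CCNCC5)cc4oc3=O)nc2c(C)n1` gives 340 ng.h/mL. Compound 1 stands highest of the three, and its separation from both compound 3 and compound 2 is beyond the scatter. The difference between the core of compound 1 and the core of compound 3 is not broken down here.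

Compound 3 and compound 2 differ in one place only: hydrogen in place of methyl on an amine nitrogen in a ring. This change gave a 1.6-fold lower number from compound 3 to compound 2 (0.19 log units; within the scatter), a step within the scatter, so the two numbers cannot be ranked with confidence.

Compound 4 `Cc1cn2nc(-c3cc(=O)n4cc(N5CCNCC5)ccc4n3)cc2c(C)n1` has not yet been measured in this assay. It relates to compound 1 as compound 2 relates to compound 3: hydrogen in place of methyl on an amine nitrogen in a ring. The place of the change is described in the same words for both pairs, so this is the same change, made on the core of compound 1 instead of the core of compound 3.

The expectation for compound 4 rests on one measured example, because a 1.6-fold lower number from compound 3 to compound 2 (0.19 log units; within the scatter) moved the number only within the scatter. Compound 4 is therefore expected to give 1300 ng.h/mL. The estimated range for compound 4 runs from 500 ng.h/mL to 3000 ng.h/mL. The expected step is a 1.6-fold lower number from compound 1 to compound 4 (0.21 log units; within the scatter), which is estimated to stay within the scatter.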

Compound 4, area under the concentration-time curve: 380 ng.h/mL
Compound 4: middle estimate off by 3.4-fold (0.53 log units), on the high side; the measured number lies below the stated range.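

Removing the methyl from the ring amine, which turns 4-methylpiperazin-1-yl into piperazin-1-yl, has a clear effect on the core of compound 1: in this assay the change gives a 5.5-fold lower number from compound 1 to compound 4 (0.74 log units; beyond the scatter). The size of the step therefore did not carry over from one core to the other, as the two pairs show when set side by side: the same change on two cores in this assay, a 1.6-fold lower number (0.19 log units; within the scatter) from compound 3 to compound 2 and a 5.5-fold lower number (0.74 log units; beyond the scatter) from compound 1 to compound 4, 3.5-fold (0.55 log units) apart, beyond the scatter of two such steps

This shows that a step measured on one core can be a poor guide to the same change on another core in this series, but two pairs cannot show why the cores differ or which size of step would be more typical. The data also cannot establish a shared direction for the change, since the step on the core of compound 3 lies within the scatter.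

The compounds shown carry only methyl or hydrogen on this ring nitrogen, which leaves open how an ethyl group, an acetyl group or a longer chain ending in an alcohol would behave there on either core. As far as these compounds go, it also remains open whether a third core would show a small step, a large one, or something else.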